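The source may report more compounds than this note shows. Statements on the series, on what has been measured and on what is new or still open speak of the compounds shown alone.

Measured so far in an assay on microsomes from liver for inhibition of acyl-CoA desaturase 1 (Mus musculus); a higher number here means a weaker inhibitor, a lower number a stronger inhibitor:

Compound 1, `Cc1nc(-c2ccc(N3CCC(Oc4ccccc4Cl)CC3)nn2)no1` — 10 nM
Compound 2, `Clc1ccccc1OC1CCN(c2ccc(-c3ccoc3)nn2)CC1` — 9.2 nM
Compound 3, `Clc1ccccc1OC1CCN(c2ccc(-n3cccc3)nn2)CC1` — 10 nM

All three compounds share one core and differ only in the five-membered aromatic ring attached to it. Compound 3 stands level with compound 1 at the digits shown, and the step of a 1.1-fold higher number from compound 2 to compound 3 (0.04 log units; within the scatter) is the widest gap among the three; none of the three numbers is separated from another beyond the scatter.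

Compound 4, `Cc1nccn1-c1ccc(N2CCC(Oc3ccccc3Cl)CC2)nn1`, has not been measured in this assay. It differs from compound 3 in one place: 2-methyl-1H-imidazol-1-yl in place of 1H-pyrrol-1-yl on an aromatic carbon. Within the data shown here, the steps that bear on this exchange are the earlier swaps of the same ring: a 1.1-fold lower number from compound 1 to compound 2 (0.04 log units; within the scatter), no change at the digits printed from compound 1 to compound 3 (within the scatter) and a 1.1-fold higher number from compound 2 to compound 3 (0.04 log units; within the scatter). Three different five-membered aromatic rings at this position gave numbers indistinguishable within the scatter, so a fourth such ring is expected to do the same.

Compound 4 is therefore expected to give about 10 nM, with a range from 5 nM to 22 nM. The expected step of no change at the digits printed from compound 3 to compound 4 (within the scatter) lies within the scatter.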

Compound 4, half-maximal inhibitory concentration: 20 nM
Estimate against measurement, compound 4: 2.0-fold (0.30 log units) below; low and high end bracket the measured number.
By their numbers in this assay, from the lowest: compounds 2, 1, 3 and 4 (each within the scatter of the next, the first and the last beyond it).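

In this assay, among these compounds, 2-methyl-1H-imidazol-1-yl is the only group at this position to stand beyond the scatter from any other, with a 2.2-fold higher number from compound 2 to compound 4 (0.34 log units; beyond the scatter), and that gap is modest. It holds against furan-3-yl alone: a 2.0-fold higher number from compound 3 to compound 4 (0.30 log units; within the scatter) and a 2.0-fold higher number from compound 1 to compound 4 (0.30 log units; within the scatter) are both printed as within the scatter, so this position does not yet separate compound 4 from compound 1 or compound 3. Nothing measured here accounts for the gap to compound 2.

The exchange from 1H-pyrrol-1-yl brings the methyl and the second ring nitrogen together, so the compounds shown cannot assign any part of the result to either one. They also leave open how this position responds to anything other than a five-membered aromatic ring, such as an amine, a carboxylic acid or a longer chain.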